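From methyl to pyridin-3-yl on compound 2

The source may hold more compounds than are shown below. What is called first, only, known or untested is meant among the compounds shown, and "the series" means these compounds.

Measured in an ADME assay (liver) for metabolic stability, with Liver microsome (Rattus norvegicus) as the target, using microsomes and NADPH, with a stated time of 30 min, at 37 degrees C, tested at 1 uM; a higher number here means faster removal of the compound, a lower number slower removal:
- compound 1 `N#Cc1cc(C(O)(C(F)(F)F)C(F)(F)F)cnc1-c1ccc(S(=O)(=O)c2ccc(N)nc2)cc1`: 27 mL.min-1.g-1
- compound 2 `CNc1nc(S(=O)(=O)c2ccc(N)nc2)ccc1-c1ccc(C(C)(O)C(F)(F)F)cn1`: 21 mL.min-1.g-1

The two values lie within the usual scatter of each other, so they set no order between compound 1 and compound 2. Compound 3 `CC(O)(c1ccc(-c2ccc(S(=O)(=O)c3ccc(N)nc3)nc2Nc2cccnc2)nc1)C(F)(F)F` keeps the rest of compound 2 and carries pyridin-3-yl in place of methyl on a nitrogen on an aromatic ring. Going by the values given here, no measured pair shows a change at this place, so the data give no direct guide to its effect in this assay. The expectation is therefore no step beyond the scatter, in either direction, with compound 2 at 21 mL.min-1.g-1 as the only anchor. The expected step is a 1.2-fold higher number from compound 2 to compound 3 (0.08 log units; within the scatter). For compound 3 the estimate is 25 mL.min-1.g-1, with an expected range from 10 mL.min-1.g-1 to 60 mL.min-1.g-1.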

Compound 3, intrinsic clearance in microsomes: 142 mL.min-1.g-1
Compound 3: the middle estimate sits 5.7-fold (0.75 log units) below what was measured, outside the stated range (above it).
By their numbers in this assay, from the lowest: compounds 2 and 1 (each within the scatter of the next); then compound 3.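

In this assay the substituent on this nitrogen proves to matter: exchanging methyl for pyridin-3-yl gives a 6.8-fold higher number from compound 2 to compound 3 (0.83 log units; beyond the scatter) and so provides the first step beyond the scatter among the compounds shown. Going by these compounds alone, a higher number here means faster removal, so compound 3 is cleared faster than compound 2, and the earlier compounds offered no view of a change at this place. Nothing available here accounts for the size of this rise.

The compounds shown leave open whether phenyl on this nitrogen, which lacks the ring nitrogen of pyridin-3-yl, would give a step of similar size, or whether a longer chain such as ethyl would already move the number. They also leave open whether the same exchange would have a like effect on the core of compound 1.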